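The source may hold more compounds than are shown below. What is called first, only, known or untested is meant among the compounds shown, and "the series" means these compounds.

Working notes, imidazole and thiazole variants on the shared core.

Three compounds share the core of compound 1 `Cc1ccc(CN2CCN(c3cccc4[nH]c(-c5ccc(C(C)(C)C)cc5)nc34)CC2)o1` and differ only in the aromatic group on the saturated chain carbon bound to the amine nitrogen in the ring. In an assay on isolated protein for displacement of a labelled ligand from Gonadotropin-releasing hormone receptor (Homo sapiens) (on this read-out higher numbers stand for weaker inhibition and lower numbers for stronger inhibition), compound 1 gives 705 nM. Compound 2 `Cc1nc(CN2CCN(c3cccc4[nH]c(-c5ccc(C(C)(C)C)cc5)nc34)CC2)c(C)s1` gives 21 nM in this assay, the second highest of the three numbers; compound 3 `CCCn1cnc(CN2CCN(c3cccc4[nH]c(-c5ccc(C(C)(C)C)cc5)nc34)CC2)c1C` gives 12 nM. The steps of a 34-fold lower number from compound 1 to compound 2 (1.53 log units; beyond the scatter) and a 59-fold lower number from compound 1 to compound 3 (1.77 log units; beyond the scatter) are both large, while a 1.8-fold lower number from compound 2 to compound 3 (0.24 log units; within the scatter) is within the scatter.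

Compound 4 `CCCCn1cnc(CN2CCN(c3cccc4[nH]c(-c5ccc(C(C)(C)C)cc5)nc34)CC2)c1C` is not yet measured. The change 1-butyl-5-methyl-1H-imidazol-4-yl in place of 2,5-dimethyl-1,3-thiazol-4-yl on a saturated chain carbon bound to an amine nitrogen in a ring is the thiazole-to-imidazole exchange already seen in the step from compound 2 to compound 3, with a longer chain on the imidazole nitrogen. That earlier step bears most directly on it and was within the scatter, so a step of similar size, downward at most and not clearly beyond the scatter, is expected as a 1.5-fold lower number from compound 2 to compound 4 (0.18 log units; within the scatter). Compound 4 is therefore estimated at 14 nM in this assay, with a range from 5 nM to 40 nM, anchored on compound 3 at 12 nM.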

Compound 4, half-maximal inhibitory concentration: 46 nM
Beside the measured number, compound 4's estimate is 3.3-fold (0.52 log units) below it; measured number outside the range, above it.
By their numbers in this assay, from the lowest: compounds 3 and 2 (each within the scatter of the next); then compound 4; then compound 1.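

The position tolerates the change of chain length on the imidazole nitrogen less well than compound 2 and compound 3 alone suggested: 1-butyl in place of 1-propyl gives a 3.8-fold higher number from compound 3 to compound 4 (0.58 log units; beyond the scatter) with only that chain altered. The exchange of 2,5-dimethyl-1,3-thiazol-4-yl for an imidazole therefore depends on the chain carried, since the 1-butyl-5-methyl-1H-imidazol-4-yl group gives a 2.2-fold higher number from compound 2 to compound 4 (0.34 log units; beyond the scatter) and so lies beyond the scatter, where the 1-propyl group stayed within it. Compound 4 still holds much of the advantage over the furan, with a 15-fold lower number from compound 1 to compound 4 (1.19 log units; beyond the scatter) as the step from that group.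

Only the propyl and butyl chains are shown, so an ethyl or pentyl chain, or a chain ending in an amine, could still fit or break any trend with length. Nothing shown gives a reason for the rise with the longer chain.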